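The compounds below may be only part of what the source reports. "The series", "measured", "known", "first", "only" and "open" are said of these compounds alone.

Three compounds that share one core and differ at the end of the chain on the ring oxygen have been measured in a functional assay on SK-BR-3 cells (Homo sapiens) for antiproliferative activity; a lower number here means a stronger inhibitor, a higher number a weaker inhibitor. Compound 1 (`CC(C)=CCc1cc(C(=O)Nc2cc3ccc(OCCC4CCCCN4)c(C)c3oc2=O)ccc1O`) gives 640 nM. Compound 2 (`CC(C)=CCc1cc(C(=O)Nc2cc3ccc(OCCCN4CCCCC4)c(C)c3oc2=O)ccc1O`) reads > 50000 nM, which is a limit of the assay and not a number. Compound 3 (`CC(C)=CCc1cc(C(=O)Nc2cc3ccc(OCCCNCC(=O)O)c(C)c3oc2=O)ccc1O`) gives 7570 nM, the higher of the two true numbers.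

Compound 4 (`CC(C)=CCc1cc(C(=O)Nc2cc3ccc(OCCCNCCO)c(C)c3oc2=O)ccc1O`) is made from compound 3 by one change, hydroxymethyl in place of carboxy on a saturated chain carbon bound to an amine nitrogen. Going by the values given here, no measured step makes this exact swap, so the guidance is indirect. The nearest steps are a 12-fold higher number from compound 1 to compound 3 (1.07 log units; beyond the scatter) and an at least 6.6-fold lower number from compound 2 to compound 3 (0.81 log units; beyond the scatter), and the widest is an at least 78-fold higher number from compound 1 to compound 2 (1.89 log units; beyond the scatter). All three lie beyond the scatter, so changes at this chain end can matter greatly, but they do not point one way. Neither compound 1 nor compound 2 carries a carboxy, yet they fall on opposite sides of compound 3. The lean towards a lower number rests only on compound 1, at 640 nM. The expected change is therefore modest, an estimated 2.2-fold lower number from compound 3 to compound 4 (0.34 log units; beyond the scatter) in this assay. For compound 4 the estimate is 3500 nM, with an expected range of 800 nM to 18000 nM.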

Compound 4, half-maximal inhibitory concentration: 610 nM
The estimate for compound 4 lay 5.7-fold (0.76 log units) above the measured number; the measured number lies below the stated range.
By their numbers in this assay, from the lowest: compounds 4 and 1 (each within the scatter of the next); then compound 3. At a limit, above all of these: compound 2.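

In this assay, replacing carboxy with hydroxymethyl on a saturated chain carbon bound to an amine nitrogen gives a 12-fold lower number from compound 3 to compound 4 (1.09 log units; beyond the scatter), so this one small change at the chain end has a large effect while the rest of the molecule stays the same. The open (2-hydroxyethyl)amino end also cannot be told apart from the piperidin-2-yl end, with a 1.0-fold lower number from compound 1 to compound 4 (0.02 log units; within the scatter), so among these compounds a ring at the chain end is not required for a number in this range. The value of compound 2 is a limit of the assay and not a number, and the change from its piperidin-1-yl end to (2-hydroxyethyl)amino reads as an at least 81-fold lower number from compound 2 to compound 4 (1.91 log units; beyond the scatter): the limit of > 50000 nM in this assay, at which 1 of the 4 values shown sits.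

The compounds shown leave open whether the hydroxyl of the hydroxymethyl group is needed or whether losing the carboxy is enough, a question that a methyl or methoxymethyl group in the same place would address. They also leave open whether a primary amide there would track with compound 3 or compound 4, and how a longer chain such as 3-hydroxypropyl on the amine would read.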